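What one added methoxy may do

This account rests on a few compounds, and the source may have more. Where it says the series, first, only, none or still open, it means among the compounds named here.

Compound 1 `COc1ccc(-c2nc3cc(C(F)(F)F)ccc3[nH]2)c(OC)c1OC` gives 93000 nM
Compound 2 `COc1ccc(-c2nc3cc([N+](=O)[O-])ccc3[nH]2)c(OC)c1` gives > 100000 nM as a limit of the assay

Compound 2 stands in an ADME assay on MT4 cells (Homo sapiens) for cytotoxicity, read by MTT assay, with a stated time of 96 h (on this read-out higher numbers stand for lower toxicity in this test and lower numbers for higher toxicity in this test), at the limit of > 100000 nM in this assay, at which 1 of the 2 values shown sits, and so has no exact number. Compound 3 `COc1ccc(-c2nc3cc([N+](=O)[O-])ccc3[nH]2)c(OC)c1OC` differs from compound 2 by methoxy in place of hydrogen on an aromatic carbon, ortho to two methoxy groups (methoxy in place of hydrogen on an aromatic carbon). Within the data shown here, no measured pair shows this change alone. The methoxy groups of compound 3 also stand on compound 1, and compound 1 gives 93000 nM in this assay so little or no step beyond the scatter is expected, toward lower numbers if any. The expected step is an at least 1.1-fold lower number from compound 2 to compound 3 (0.04 log units; that floor lies within the scatter) as an estimate only. For compound 3 the estimated value is 90000 nM (expected range 40000 nM to 100000 nM).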

Compound 3, half-maximal cytotoxic concentration: > 100000 nM
Compound 3 ended at the assay's limit; the forecaster's own chance of this, stated with the estimate: 50%; middle value at least 1.1-fold (0.04 log units) from the limit.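

In this assay nitro in place of trifluoromethyl gives an at least 1.0-fold higher number from compound 1 to compound 3 (0.03 log units; that floor lies within the scatter) and so shows no firm shift from this change. The effect of methoxy on the aromatic carbon ortho to two methoxy groups cannot be read, because compound 2 and compound 3 both end at the same limit: the limit of > 100000 nM in this assay, at which 2 of the 3 values shown sit.

From the compounds shown here alone, whether methoxy at this position changes the toxicity reading at all therefore stays open. Also open, going by these compounds, is what an amine or a carboxylic acid at the same position would give.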